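A few compounds are considered here, and "the series" means these few. Any claim that something is new, unique, unknown or untested is made for them only; others in the source may bear on it.

Compound 1 `Cc1ccccc1-c1nc(CN2CCC(C(=O)NCCCN3CCCC(C(C)C)C3)CC2)c(C)o1` and compound 2 `Cc1oc(-c2c(Br)cccc2Br)nc1CN1CCC(C(=O)NCCCN2C[C@H](C)C[C@H](C)C2)CC1` share a core built around a five-membered aromatic ring with one nitrogen and one oxygen, a methyl on that ring, and an aryl group on the carbon between the two ring heteroatoms, linked through a piperidine amide to a second saturated ring bearing alkyl groups. In an ADME assay on microsomes from liver (Rattus norvegicus) for metabolic stability, read by LC-MS, using NADPH, at 37 degrees C (on this read-out higher numbers stand for a longer-lived compound and lower numbers for a shorter-lived compound), compound 1 gives 0.323 h, and in the same assay compound 2 gives 0.035 h. Of the two numbers, compound 2 stands lowest, and the gap to compound 1 lies beyond the scatter of repeated measurement.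

Compound 3 `Cc1cc(C)cc(-c2nc(CN3CCC(C(=O)NCCCN4C[C@H](C)C[C@H](C)C4)CC3)c(C)o2)c1` is the next compound in line and is not yet measured. It is derived from compound 2 by a single change: 3,5-dimethylphenyl in place of 2,6-dibromophenyl on an aromatic carbon. Among the compounds with values here, no step between two measured compounds isolates this particular exchange, so its effect is not known from the data at hand. Still, the number for compound 3 is expected to rise, with a step of a 3.4-fold higher number from compound 2 to compound 3 (0.54 log units; beyond the scatter) reaching beyond the scatter, because compound 1 gives 0.323 h in this assay while carrying a methyl-substituted phenyl in the same position. Compound 3 is estimated at 0.12 h, within a range from 0.04 h to 0.4 h.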

Compound 3, half-life: < 0.5 h
Compound 3: no number, only a limit (the forecaster's own chance of this, stated with the estimate: 5%); the middle value is on the limit's open side.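

In this assay compound 3 gives < 0.5 h, which is a limit of the assay and not a number. The step from compound 2 to compound 3 therefore cannot be read, because the result sits at a limit: the limit of < 0.5 h in this assay, at which 1 of the 3 values shown sits.

The compounds shown leave open how far 3,5-dimethylphenyl in place of 2,6-dibromophenyl alone moves the half-life, or in which direction.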